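Replacing the indole with a benzodioxin: cytotoxicity outlook

This account rests on a few compounds, and the source may have more. Where it says the series, first, only, none or still open, it means among the compounds named here.

Measured compounds:
Compound 1, `CC(C)N(Cc1cccc(OCCCCCC(=O)O)c1)C(=O)c1ccc(-c2ccncc2)cc1`: in an ADME assay on BJ cells (Homo sapiens) for cytotoxicity, read by CellTiter-Glo and resazurin assay, with a stated time of 72 h (a lower number here means that less compound is needed, a higher number that more compound is needed for the effect), compound 1 gives > 26000 nM, which is a limit of the assay and not a number.
Compound 2, `CC(C)N(Cc1cccc(OCCCCCC(=O)O)c1)C(=O)c1ccc(-c2ccc3[nH]ccc3c2)cc1`: in this assay compound 2 gives > 26000 nM, again a limit of the assay rather than a number.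

For the measured compounds named here, compound 2 therefore stands only at a limit, and so does its one neighbour: the limit of > 26000 nM in this assay, at which 2 of the 2 values shown sit. Going by the values given here, the single measured step, a step that the two limits leave unreadable from compound 1 to compound 2, cannot be read because both ends are limits, so no direction or size can be taken from it.

Compound 3 is `CC(C)N(Cc1cccc(OCCCCCC(=O)O)c1)C(=O)c1ccc(-c2ccc3c(c2)OCCO3)cc1`. It differs from compound 2 in one place: 2,3-dihydro-1,4-benzodioxin-6-yl in place of 1H-indol-5-yl on an aromatic carbon. Among the compounds with values here, no measured step bears on this change, and the one step available is unreadable.

Within the data shown here, with both measured compounds at the limit, the only expectation that the numbers support is that compound 3 also sits at or beyond that limit, with no step beyond the scatter expected, a step that the limit leaves unreadable from compound 2 to compound 3. Compound 3 is estimated at 40000 nM, in a range from 20000 nM to 100000 nM, most likely reported again as a limit only.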

Compound 3, half-maximal effective concentration: > 21900 nM
Compound 3 ended at the assay's limit (the forecaster's own chance of this, stated with the estimate: 80%); the middle value lies beyond the limit too.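

For the compounds shown here, no step between compound 1, compound 2 and compound 3 can be read: all three results in this assay are limits of the assay and not numbers. The compounds shown leave open what the actual value of each compound is, and whether exchanging pyridin-4-yl, 1H-indol-5-yl and 2,3-dihydro-1,4-benzodioxin-6-yl changes it at all.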